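Methoxy in Place of Hydrogen: Cytotoxicity Notes

A few compounds are considered here, and "the series" means these few. Any claim that something is new, unique, unknown or untested is made for them only; others in the source may bear on it.

Measured compounds:
- compound 1 `O=C1OC[C@H](Cc2ccccc2)[C@H]1Cc1ccc(Cl)cc1` — "not determined" (no result reported)
- compound 2 `O=C1OC[C@H](Cc2ccccc2)[C@H]1Cc1ccc(Cl)c(Cl)c1` — 26000 nM

In a functional assay on HeLa cells (Homo sapiens) for cytotoxicity, read by WST assay, with a stated time of 48 h (on this read-out lower numbers stand for an effect already at smaller amounts and higher numbers for an effect only at larger amounts of compound), compound 2 gives 26000 nM. Going by the values given here, this is the only number in the set; for compound 1 the entry reads "not determined" (no result reported), so compound 2 stands alone, with nothing to set it above or below. Among the compounds with values here, no step between two measured compounds exists, and no direction for the series can be read from what is at hand.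

Compound 3 `COc1ccccc1C[C@H]1COC(=O)[C@@H]1Cc1ccc(Cl)c(Cl)c1` differs from compound 2 by methoxy in place of hydrogen on an aromatic carbon, the methoxy entering on an aromatic carbon of the six-membered aromatic ring of carbon only, ortho to a large group. Within the data shown here, with no comparable step available, the expected step from compound 2 to compound 3 in this assay is a 1.2-fold lower number from compound 2 to compound 3 (0.07 log units; within the scatter), small and not expected to reach beyond the usual scatter in either direction. Compound 3 is estimated at 22000 nM, with a range from 8000 nM to 60000 nM.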

Compound 3, half-maximal effective concentration: 24000 nM
Compound 3: the middle estimate sits 1.1-fold (0.04 log units) below what was measured, within the range that was stated.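

In this assay, going by these compounds alone, the change of methoxy in place of hydrogen on an aromatic carbon, ortho to a large group, gives a 1.1-fold lower number from compound 2 to compound 3 (0.03 log units; within the scatter) and so supplies the first step that can be read. At this position, the change from phenyl to 2-methoxyphenyl leaves compound 3 within the scatter of compound 2, so this one replacement does not separate the two compounds on this read-out. No available evidence bears on the reason for this result.

The compounds shown leave open whether a group other than methoxy, such as an amine, a carboxylic acid or a longer chain, would give a step beyond the scatter at this position. A single step also cannot show whether methoxy would behave the same way on another aromatic carbon of this ring.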